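The source may report more compounds than this note shows. Statements on the series, on what has been measured and on what is new or still open speak of the compounds shown alone.

Compound 1, `Cc1ccccc1-c1nn(-c2ccccc2Cl)cc1CNCCN1CCN(C)CC1`: > 20000 nM
Compound 2, `CCCN1CCC(CNCc2cn(-c3ccc(F)cc3F)nc2-c2ccccc2C)CC1`: > 20000 nM

In an ADME assay on Huh-7 cells (Homo sapiens) for cytotoxicity (on this read-out lower numbers stand for higher toxicity in this test and higher numbers for lower toxicity in this test), compound 1 gives > 20000 nM, which is a limit of the test rather than a number. Compound 2 likewise gives > 20000 nM, also a limit. Compound 1 therefore stands at the limit of > 20000 nM in this assay, at which 2 of the 2 values shown sit, with no measured number to place it against. Compound 3, `Cc1ccccc1-c1nn(-c2cccc(Cl)c2)cc1CNCCN1CCN(C)CC1`, is yet to be measured in this assay; it differs from compound 1 by 3-chlorophenyl in place of 2-chlorophenyl on an aromatic nitrogen. Among the compounds with values here, with two limits and no measured step, no shift beyond the scatter is expected. Compound 3 is estimated at 30000 nM, between 15000 nM and 80000 nM, which means an expected step that the limit leaves unreadable from compound 1 to compound 3.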

Compound 3, half-maximal cytotoxic concentration: 16000 nM
For compound 3 the middle estimate is 1.9-fold (0.27 log units) above the measured one, within the range that was stated.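

In this assay, within the data shown here, this aromatic nitrogen is the first place where a change yields a readable number rather than a limit, since compound 3 gives 16000 nM. Placing 3-chlorophenyl there in place of 2-chlorophenyl gives an at least 1.2-fold lower number from compound 1 to compound 3 (0.09 log units; that floor lies within the scatter), so this change in the chlorine's place shows no firm shift in toxicity in this test. The full size of the step stays unknown because compound 1 carries only a limit: the limit of > 20000 nM in this assay, at which 2 of the 3 values shown sit.

On these data alone, how a plain phenyl or a methoxyphenyl group on this nitrogen would read in this assay remains open.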